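Swapping the aryl substituent pattern on a shared chromone core

The compounds below may be only part of what the source reports. "The series", "measured", "known", "first", "only" and "open" are said of these compounds alone.

Compound 2 `CCC1=C(O)c2c(oc(-c3ccc(O)c(C)c3C)cc2=O)C(CC)(CC)C1=O` gives the lowest of the two numbers recorded in a functional assay on KBVIN cells (Homo sapiens) for antiproliferative activity, read by sulforhodamine B assay, with a stated time of 3 days (a higher number here means that more compound is needed for the effect, a lower number that less compound is needed), at 2.75 uM. Going by the values given here, its only neighbour is compound 1 `CCC1=C(O)c2c(oc(-c3ccc(C)c(F)c3)cc2=O)C(CC)(CC)C1=O`, which in this assay gives 2.95 uM; the two sit within the scatter of each other, with a 1.1-fold lower number from compound 1 to compound 2 (0.03 log units; within the scatter), so no order between them can be claimed.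

The unmeasured compound 3 `CCC1=C(O)c2c(oc(-c3ccc(F)c(C)c3)cc2=O)C(CC)(CC)C1=O` differs from compound 2 in one place: 4-fluoro-3-methylphenyl in place of 4-hydroxy-2,3-dimethylphenyl on an aromatic carbon. Among the compounds with values here, the entering 4-fluoro-3-methylphenyl is a close relative of the 3-fluoro-4-methylphenyl carried by compound 1, so the one measured step that bears on this change is the one from the fluoro-methyl aryl of compound 1 to the hydroxy-dimethyl aryl of compound 2, and that step was flat, at a 1.1-fold lower number from compound 1 to compound 2 (0.03 log units; within the scatter). Nothing in these two measurements suggests that exchanging one aryl for another of this kind moves the number beyond the scatter.

Compound 3 is therefore expected to give a step of about a 1.1-fold higher number from compound 2 to compound 3 (0.04 log units; within the scatter), which is no real change. The estimate for compound 3 in this assay is 3 uM, with a range from 1.5 uM to 6 uM.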

Compound 3, concentration for half-maximal effect: 1.62 uM
Estimate against measurement, compound 3: 1.9-fold (0.27 log units) above; the range from low to high includes it.
By their numbers in this assay, from the lowest: compounds 3, 2 and 1 (each within the scatter of the next).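

In this assay, the place next to the ring oxygen now has a second exchange to read: 4-fluoro-3-methylphenyl entering for 4-hydroxy-2,3-dimethylphenyl gives a 1.7-fold lower number from compound 2 to compound 3 (0.23 log units; within the scatter) and so leaves the number within the scatter, even though the hydrogen-bond donor and acceptor counted on the leaving group are gone. Going by these compounds alone, the first direct comparison of the two fluoro-methyl aryl groups, which carry the same two substituents in swapped places, gives a 1.8-fold lower number from compound 1 to compound 3 (0.26 log units; within the scatter) and is likewise no real change, so neither the swap nor the hydroxy-bearing aryl separates these compounds at this position. No measurement here bears on why the number holds across these three aryl groups.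

The exchange from compound 2 to compound 3 alters the hydroxy, the fluorine and the number of methyl groups at once, so the share of each stays unresolved. On these data alone, all three aryl groups carry only small substituents, and it remains open whether an amine or a carboxylic acid on the phenyl ring, or a longer chain in place of methyl, would move the number beyond the scatter.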